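Shortening the Side Chain of Compound 1

The source may hold more compounds than are shown below. What is called first, only, known or untested is meant among the compounds shown, and "the series" means these compounds.

Compound 1 `N=C(N)NCCC[C@H](NC(=O)CN(c1nc(Cl)nc2[nH]cnc12)C1CC1)C(=O)OCc1ccccc1` has been tested in a functional assay on the whole organism (Tail, strain ICR) with Mus musculus as the target, in the tail flick test, with a stated time of 30 min, at a dose of 25 umol/kg by the oral route (on this read-out higher numbers stand for a stronger effect at the one dose given and lower numbers for a weaker effect), where compound 1 gives 23.2%. On the three numbers recorded in this assay it stands in the middle, and all three lie within the scatter of one another: compound 2 `CC(C)[C@H](NC(=O)CN(c1ncnc2c1ncn2C1CCCCO1)C1CC1)C(=O)OCc1ccccc1` gives 21.8%, and compound 3 `CC[C@H](C)[C@H](NC(=O)CN(c1ncnc2c1ncn2C1CCCCO1)C1CC1)C(=O)OCc1ccccc1` gives 25.6%. The three compounds thus show the same level of effect at this dose, with nothing yet separating them.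

Compound 4 `C[C@H](NC(=O)CN(c1nc(Cl)nc2[nH]cnc12)C1CC1)C(=O)OCc1ccccc1` differs from compound 1 in one place: a hydrogen atom in place of a group of 6 heavy atoms (3 carbon, 3 nitrogen; no ring), on a saturated chain carbon, two bonds along the chain from an amide-type nitrogen and a carbonyl carbon. Within the data shown here, the only step between measured compounds that touches the side chain on that carbon is the one from compound 2 to compound 3, where a methyl replaces a hydrogen one bond further along the chain; in this assay it amounts to a number 3.8 percentage points higher from compound 2 to compound 3 (within the scatter). Among the measured compounds shown here, that step is small and within the scatter, and no measured step removes a group of the size leaving here, so the data give no ground to expect a move beyond the scatter in either direction.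

Compound 4 is therefore expected to give about 20% in this assay, within a range of 8% to 32%. This estimate means an expected step of a number 3.2 percentage points lower from compound 1 to compound 4 (within the scatter).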

Compound 4, a percentage reported as activity, at one dose (the size of the read-out at that dose, not a potency): 41.2%
Compound 4: the middle estimate sits 21.2 percentage points below what was measured; the whole stated range lies below it.
By their numbers in this assay, from the lowest: compounds 2, 1 and 3 (each within the scatter of the next); then compound 4.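

In this assay, among these compounds, replacing the group of 6 heavy atoms (3 carbon, 3 nitrogen; no ring) with a hydrogen atom gives a number 18 percentage points higher from compound 1 to compound 4 (beyond the scatter) and is the only step in this set printed as beyond the scatter. The earlier step, a methyl in place of hydrogen on a saturated chain carbon three bonds along the chain from an amide-type nitrogen and a carbonyl carbon, gave a number 3.8 percentage points higher from compound 2 to compound 3 (within the scatter) and so showed no clear effect of changing the side chain. The new result shows that, with the rest of compound 1 unchanged, the read-out at this one dose does respond to what sits on the saturated chain carbon two bonds along the chain from an amide-type nitrogen and a carbonyl carbon, though nothing presented here explains why.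

The compounds shown leave open whether the higher number depends on losing the whole group or would also follow from a shorter chain ending in an amine, a carboxylic acid or a plain propyl chain on the same carbon. They also leave open whether the step would hold at other doses or times, since this comparison rests on a single pair at one dose and one time.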